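The compounds below may be only part of what the source reports. "The series", "measured", "known", "first", "only" and "open" are said of these compounds alone.

Of the compounds shown here, three built on one shared core have been measured in an assay on cells for inhibition of cytochrome P450 11B2, mitochondrial (Homo sapiens), read by HPLC, with a stated time of 90 min; on this read-out lower numbers stand for stronger inhibition and higher numbers for weaker inhibition. Compound 1 `Fc1ccc2nc(-c3cnccn3)n(C3CC3)c2c1` gives 541 nM. Among the measured compounds shown here, compound 2 `Fc1ccc2nc(-c3ccnnc3)n(C3CC3)c2c1` gives 330 nM, and the only single-point step in the set, a 1.6-fold lower number from compound 1 to compound 2 (0.21 log units; within the scatter), exchanges one six-membered ring for another without any change of potency that could be trusted. Compound 3 `Fc1cc2nc(-c3cncnc3)n(C3CC3)c2cc1F` gives 22 nM, the lowest of the three numbers; its gap to compound 2 and its larger gap to compound 1 both lie beyond the scatter, so compound 3 stands apart as the most potent of the three.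

Compound 4 `Fc1cc2nc(-c3cncnc3NCCC(F)(F)F)n(C3CC3)c2cc1F` differs from compound 3 in one place: (3,3,3-trifluoropropyl)amino in place of hydrogen on an aromatic carbon. For the measured compounds named here, no measured step in this set bears on such a change; the step from compound 1 to compound 2 swaps rings rather than adding a substituent, and compound 3 is the only compound carrying this particular ring. With nothing to lean on, the expectation for the step from compound 3 to compound 4 is one of no change beyond the scatter, a 1.1-fold higher number from compound 3 to compound 4 (0.06 log units; within the scatter). Compound 4 is therefore expected to come in at about 25 nM, with a range from 8 nM to 80 nM.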

Compound 4, half-maximal inhibitory concentration: 3 nM
Compound 4: middle estimate off by 8.3-fold (0.92 log units), on the high side; measured number outside the range, below it.
By their numbers in this assay, from the lowest: compound 4; then compound 3; then compounds 2 and 1 (each within the scatter of the next).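

In this assay the aromatic carbon next to the ring nitrogen and ortho to a large group, on the six-membered aromatic ring with 2 nitrogen, proves open to substitution: with (3,3,3-trifluoropropyl)amino in place of hydrogen there is a 7.3-fold lower number from compound 3 to compound 4 (0.87 log units; beyond the scatter), a step beyond the scatter. Compound 3 carries only hydrogen at this carbon, and compound 1 and compound 2 differ from each other only by a ring exchange, so none of them showed that a substituent placed here could go with a lower number, and compound 4 now stands lowest of the four at 3 nM. The data offer nothing that would explain this gain.

On these data alone, whether the gain belongs to the amino nitrogen or to the fluorinated chain stays open, and a plain amine, a methylamino group or a propylamino chain without fluorine at this carbon would separate the two. As far as these compounds go, it is equally open whether the same group would have a comparable effect on the pyrazin-2-yl or pyridazin-4-yl rings of compound 1 and compound 2.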